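Sulfur in Place of Selenium on Compound 1

The compounds below may be only part of what the source reports. "The series", "measured", "known", "first", "only" and "open" are said of these compounds alone.

Measured compounds:
compound 1 `COc1ccc(CNc2nc([Se]C)nc3ccccc23)cc1` — > 100000 nM
compound 2 `C[Se]c1nc(NCc2ccccc2)c2ccccc2n1` — 83500 nM

In a functional assay on CCRF-CEM cells (Homo sapiens) for cytotoxicity, read by MTT assay, with a stated time of 72 h (on this read-out higher numbers stand for lower toxicity in this test and lower numbers for higher toxicity in this test), compound 1 gives only a limit, > 100000 nM, and no number (the limit of > 100000 nM in this assay, at which 1 of the 2 values shown sits). Compound 2 gives 83500 nM in this assay. Among the compounds with values here, the one measured step, an at least 1.1-fold lower number from compound 1 to compound 2 (0.07 log units; that floor lies within the scatter), stays within the scatter, so both compounds sit at the weakly toxic end of what this assay reads.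

Compound 3 `COc1ccc(CNc2nc(SC)nc3ccccc23)cc1` differs from compound 1 by a group of 2 heavy atoms (1 carbon, 1 sulfur; no ring) in place of a group of 2 heavy atoms (1 carbon, 1 selenium; no ring), on an aromatic carbon. Within the data shown here, no measured step covers an exchange of selenium for sulfur; the only step recorded concerns the methoxy group and was within the scatter. With nothing to point the other way, compound 3 is expected to stay close to compound 1, with a step that the limit leaves unreadable from compound 1 to compound 3 not beyond the scatter. Compound 3 is therefore estimated at 110000 nM, within 50000 nM to 300000 nM, and it may again come back as a limit.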

Compound 3, concentration lethal to 50% of the cells: > 100000 nM
Compound 3 was reported as a limit; the forecaster's own chance of this, stated with the estimate: 55%; the middle value lies beyond the limit too.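

Compound 1 and compound 3 both come back as limits in this assay, so no step can be read between them: the limit of > 100000 nM in this assay, at which 2 of the 3 values shown sit.

The compounds shown leave open whether sulfur in place of selenium on the shared core shifts this read-out in either direction.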